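A few compounds are considered here, and "the series" means these few. Any claim that something is new, unique, unknown or untested is made for them only; others in the source may bear on it.

Measured compounds:
compound 1, `CNc1nccc(N2CC[C@H](NC(=O)Nc3ccc(C)c(Cl)c3)C2)n1`: 72700 nM
compound 2, `O=C(Nc1ccc(Cl)c(C(F)(F)F)c1)N[C@H]1CCN(c2ccc3nncn3n2)C1`: 1000 nM

In a physicochemical assay for solubility, measured as kinetic solubility (on this read-out higher numbers stand for higher solubility and lower numbers for lower solubility), compound 1 gives 72700 nM, the higher of the two numbers. In this assay compound 2 gives 1000 nM, a gap that lies beyond the scatter. Compound 3, `CNc1nccc(N2CC[C@H](NC(=O)Nc3ccc(OC)cc3)C2)n1`, is not yet measured. It differs from compound 1 in one place: 4-methoxyphenyl in place of 3-chloro-4-methylphenyl on an amide-type nitrogen. Among the measured compounds shown here, no measured pair shows this change, so the direction is only expected: a modest rise from compound 1 to compound 3, a 2.1-fold higher number from compound 1 to compound 3 (0.31 log units; beyond the scatter), possibly not beyond the scatter. Compound 3 is therefore estimated at 150000 nM, within a range from 60000 nM to 400000 nM.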

Compound 3, solubility: 92600 nM
Compound 3: the middle estimate sits 1.6-fold (0.21 log units) above what was measured; the measured number falls inside the stated range.
By their numbers in this assay, from the lowest: compound 2; then compounds 1 and 3 (each within the scatter of the next).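

In this assay, among the compounds shown here, 4-methoxyphenyl in place of 3-chloro-4-methylphenyl on the amide-type nitrogen gives a 1.3-fold higher number from compound 1 to compound 3 (0.11 log units; within the scatter) and is the first step read in one place. At this position, on the shared core, the two groups stand level on this read-out, although a chlorine leaves and an oxygen enters. Nothing available gives a reason for this result. As far as these compounds go, whether a morpholine, an amine or a carboxylic acid in this same place would also stand level remains open. So does whether this step would hold on the core of compound 2.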